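From 1H-indol-1-yl to (2,4-dichlorophenyl)amino: an open step

This account rests on a few compounds, and the source may have more. Where it says the series, first, only, none or still open, it means among the compounds named here.

Measured in a functional assay on NCI-H3122 cells (Homo sapiens) for inhibition, with a stated time of 72 h; a lower number here means a stronger inhibitor of growth, a higher number a weaker inhibitor of growth:
- compound 1 `O=C(c1cc(-n2ccc3ccccc32)c(O)cc1O)N1Cc2ccccc2C1`: 7530 nM
- compound 2 `Cc1ccc2c(ccn2-c2cc(C(=O)N3Cc4ccccc4C3)c(O)cc2O)c1`: 7530 nM

Within the data shown here, compound 1, at 7530 nM, stands level with compound 2, the only other measured compound. Compound 3 `O=C(c1cc(Nc2ccc(Cl)cc2Cl)c(O)cc1O)N1Cc2ccccc2C1` keeps the core of compound 1 but exchanges one group: (2,4-dichlorophenyl)amino in place of 1H-indol-1-yl on an aromatic carbon. The exchange takes place on an aromatic carbon, ortho to a hydroxy group and para to a hydroxy group.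

Among the measured compounds shown here, only one measured step bears on this, and only loosely: no change at the digits printed from compound 1 to compound 2 (within the scatter). There, methyl took the place of hydrogen on an aromatic carbon, while 1H-indol-1-yl itself stayed in the molecule. For the measured compounds named here, that step says nothing about removing the group altogether, and no measured compound carries (2,4-dichlorophenyl)amino. The data therefore give no firm direction, so the best expectation in this assay is no step beyond the scatter, held with wide uncertainty. The expected step is a 1.5-fold lower number from compound 1 to compound 3 (0.18 log units; within the scatter). Compound 3 is estimated at 5000 nM, with an expected range of 900 nM to 25000 nM.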

Compound 3, concentration for 50% growth inhibition: 10100 nM
Estimate against measurement, compound 3: 2.0-fold (0.31 log units) below; the measured number falls inside the stated range.
By their numbers in this assay, from the lowest: compounds 1, 2 and 3 (each within the scatter of the next).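

In this assay, the exchange of 1H-indol-1-yl for (2,4-dichlorophenyl)amino gives a 1.3-fold higher number from compound 1 to compound 3 (0.13 log units; within the scatter), a step within the scatter. The earlier pair changed only a methyl on a group that stayed in place, whereas here the whole group on this aromatic carbon is replaced: the five-membered aromatic ring goes, two chlorine atoms come in, a hydrogen-bond donor is added, and the heavy-atom count stays the same, yet the reading does not move beyond the scatter, so this position accepts two quite different groups of equal size with no measurable gain or loss in growth inhibition. No measurement at hand explains this lack of change, so it stands as an observation only.

From the compounds shown here alone, all three compounds carry a large aromatic group at this position, so whether a small amine or a carboxylic acid here would shift the number remains open. Also open, going by these compounds, is whether either chlorine matters, which a plain phenylamino group would help to show, and whether any change at this position can move the number beyond the scatter at all.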